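This account rests on a few compounds, and the source may have more. Where it says the series, first, only, none or still open, it means among the compounds named here.

The series shares the core of compound 1 `Nc1nc(C(F)(F)F)cc2c1[nH]c(=O)n2Cc1ccc(NCCN2CCCC2)nc1`, varied only at the amine-bearing side chain on the pyridine-side nitrogen. In an in vitro ADME assay on microsomes from liver (Rattus norvegicus) for pharmacokinetics (a higher number here means faster removal of the compound, a lower number slower removal), compound 1 gives only a limit, < 8.5 mL.min-1.g-1, and not a number (the limit of < 8.5 mL.min-1.g-1 in this assay, at which 1 of the 3 values shown sits). Compound 2 `CN(C)CCN(C)c1ccc(Cn2c(=O)[nH]c3c(N)nc(C(F)(F)F)cc32)cn1` gives 11 mL.min-1.g-1 in this assay. Compound 3 `CN(CCN1CCCCC1)c1ccc(Cn2c(=O)[nH]c3c(N)nc(C(F)(F)F)cc32)cn1` gives 13 mL.min-1.g-1 in this assay; of the two numbers given, compound 3 and compound 2 lie within the scatter of each other, so neither stands apart. Among the compounds with values here, the steps so far: an at least 1.2-fold higher number from compound 1 to compound 2 (0.11 log units; that floor lies within the scatter); an at least 1.5-fold higher number from compound 1 to compound 3 (0.18 log units; that floor lies within the scatter); a 1.2-fold higher number from compound 2 to compound 3 (0.07 log units; within the scatter). Compound 4 `CN1CCN(CCN(C)c2ccc(Cn3c(=O)[nH]c4c(N)nc(C(F)(F)F)cc43)cn2)CC1` is not yet measured. It differs from compound 3 in that (4-methylpiperazin-1-yl in place of piperidin-1-yl on a saturated chain carbon, two bonds along the chain from a nitrogen on an aromatic ring). Within the data shown here, the step that bears most directly on this change is the one from compound 2 to compound 3, which swapped the terminal amine at the same chain position and stayed within the scatter; the other two steps are floors set by a limit. No movement beyond the scatter is therefore expected, a 1.2-fold lower number from compound 3 to compound 4 (0.07 log units; within the scatter). Compound 4 is estimated at 11 mL.min-1.g-1, in the range 6 mL.min-1.g-1 to 22 mL.min-1.g-1.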

Compound 4, intrinsic clearance in microsomes: 15 mL.min-1.g-1
The estimate for compound 4 lay 1.4-fold (0.13 log units) below the measured number; measured number inside the range.
By their numbers in this assay, from the lowest: compounds 2, 3 and 4 (each within the scatter of the next). At a limit, below all of these: compound 1.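

In this assay, 4-methylpiperazin-1-yl now joins piperidin-1-yl and dimethylamino at this place, with a 1.2-fold higher number from compound 3 to compound 4 (0.06 log units; within the scatter) and a 1.4-fold higher number from compound 2 to compound 4 (0.13 log units; within the scatter). Compounds 2, 3 and 4 therefore cannot be told apart on a saturated chain carbon, two bonds along the chain from a nitrogen on an aromatic ring, even with a second hetero atom in the six-membered ring of compound 4. The remaining step, an at least 1.7-fold higher number from compound 1 to compound 4 (0.24 log units; that floor lies within the scatter), is only a floor, set by a limit and not a number: the limit of < 8.5 mL.min-1.g-1 in this assay, at which 1 of the 4 values shown sits.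

Open, on these data alone, is whether a terminal morpholine, a carboxylic acid or a longer chain at this place would move the number beyond the scatter. Also open, as far as these compounds go, is whether the methyl on the chain nitrogen or the terminal ring carries any difference from compound 1.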